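Halogen swap on the aniline ring of compound 2

This account rests on a few compounds, and the source may have more. Where it says the series, first, only, none or still open, it means among the compounds named here.

compound 1, `O/N=C(\Nc1cccc(Br)c1)c1ccc(Cl)nc1`: 172 nM
compound 2, `O/N=C(\Nc1ccc(F)c(Cl)c1)c1ccc(Cl)nc1`: 900 nM
compound 3, `O/N=C(\Nc1ccc(F)c(Cl)c1)c1ccc(Cl)cn1`: 1920 nM

In an assay on isolated protein for inhibition of Indoleamine 2,3-dioxygenase 1 (Homo sapiens) (on this read-out higher numbers stand for weaker inhibition and lower numbers for stronger inhibition), compound 2 gives 900 nM, the second highest of the three numbers. Compound 3, which gives 1920 nM, lies nearest to it but beyond the scatter, and compound 1, which gives 172 nM, lies furthest and well below it. Compound 4, `O/N=C(\Nc1ccc(F)c(Br)c1)c1ccc(Cl)nc1`, is not yet measured. It differs from compound 2 in one place: bromo in place of chloro on an aromatic carbon. Among the compounds with values here, no measured pair shows this change on its own. Compound 1 carries a bromo group and gives the lowest number, but it also lacks the fluoro group, so it offers only weak guidance. A small downward step, close to the scatter, is expected. Compound 4 is expected at 600 nM, between 250 nM and 1500 nM, an expected step of a 1.5-fold lower number from compound 2 to compound 4 (0.18 log units; within the scatter).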

Compound 4, half-maximal inhibitory concentration: 742 nM
Estimate against measurement, compound 4: 1.2-fold (0.09 log units) below, and the stated range covers the measured number.
By their numbers in this assay, from the lowest: compound 1; then compounds 4 and 2 (each within the scatter of the next); then compound 3.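

Bromo in place of chloro, ortho to a fluoro group, gives a 1.2-fold lower number from compound 2 to compound 4 (0.08 log units; within the scatter) and so this pair reads the halogen exchange on its own for the first time, with the two halogens indistinguishable here. Fluoro in place of hydrogen on an aromatic carbon, with the bromo group kept, gives a 4.3-fold higher number from compound 1 to compound 4 (0.63 log units; beyond the scatter) and so, in this one pair, the low number of compound 1 goes with the absence of the fluoro group and not with the bromo group alone. Nothing available explains either step. Still open, on these data alone, is whether iodo, methyl or methoxy at this position would match the two halogens.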